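Methyl for Methoxy, Carried from One Core to the Other

A few compounds are considered here, and "the series" means these few. Any claim that something is new, unique, unknown or untested is made for them only; others in the source may bear on it.

Compound 1, `CCOC(=O)c1sc2ccc(NCc3nc[nH]c3C)cc2c1NC(=O)c1ccc(OC)cc1`, in a functional assay on HeLa cells (Homo sapiens) for antiproliferative activity, read by MTT assay, with a stated time of 48 h (on this read-out lower numbers stand for stronger inhibition of growth and higher numbers for weaker inhibition of growth), gives 8220 nM.
Compound 2, `CCOC(=O)c1sc2ccc(NCc3nc[nH]c3C)cc2c1NC(=O)c1ccc(C)cc1`, in this assay gives 11400 nM.
Compound 3, `CCOC(=O)c1sc2ccc(N)cc2c1NC(=O)c1ccc(OC)cc1`, in this assay reaches only a limit, > 50000 nM, and no number.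

Compound 1 and compound 2 share a core and differ in one place: methyl in place of methoxy on an aromatic carbon. This change gave a 1.4-fold higher number from compound 1 to compound 2 (0.14 log units; within the scatter). The core of compound 3 differs from the core of compound 1 in one place as well: hydrogen in place of (5-methyl-1H-imidazol-4-yl)methyl on a nitrogen on an aromatic ring. That change gave an at least 6.0-fold higher number from compound 1 to compound 3 (0.78 log units; beyond the scatter), with compound 3 sitting at the limit of > 50000 nM in this assay, at which 1 of the 3 values shown sits.

Compound 4, `CCOC(=O)c1sc2ccc(N)cc2c1NC(=O)c1ccc(C)cc1`, has not yet been measured. It differs from compound 3 by methyl in place of methoxy on an aromatic carbon. The place of this change reads the same, word for word, as in the pair of compound 1 and compound 2, so it is the same change made on the second core.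

The expectation for compound 4 rests on the pair of compound 1 and compound 2, whose step a 1.4-fold higher number from compound 1 to compound 2 (0.14 log units; within the scatter) lies within the scatter. On the second core the same change is therefore expected to give a step that the limit leaves unreadable from compound 3 to compound 4. Compound 3 itself gives only a limit. Compound 4 is accordingly expected most likely to reach only the limit as well, with an estimate of 80000 nM and a range running from 40000 nM to 200000 nM.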

Compound 4, concentration for 50% growth inhibition: 24400 nM
Beside the measured number, compound 4's estimate is 3.3-fold (0.52 log units) above it; measured number outside the range, below it.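

In this assay, carrying methyl in place of methoxy to the second core gave an at least 2.0-fold lower number from compound 3 to compound 4 (0.31 log units; beyond the scatter), against a 1.4-fold higher number from compound 1 to compound 2 (0.14 log units; within the scatter) on the first core, so the step did not transfer unchanged: the same change on two cores in this assay, a 1.4-fold higher number (0.14 log units; within the scatter) from compound 1 to compound 2 and an at least 2.0-fold lower number (0.31 log units; beyond the scatter) from compound 3 to compound 4, at least 2.8-fold (0.45 log units) apart, beyond the scatter of two such steps Hydrogen in place of (5-methyl-1H-imidazol-4-yl)methyl likewise gave a 2.1-fold higher number from compound 2 to compound 4 (0.33 log units; beyond the scatter) with the 4-methylphenyl group present, against an at least 6.0-fold higher number from compound 1 to compound 3 (0.78 log units; beyond the scatter) with the 4-methoxyphenyl group present: the same change on two cores in this assay, an at least 6.0-fold higher number (0.78 log units; beyond the scatter) from compound 1 to compound 3 and a 2.1-fold higher number (0.33 log units; beyond the scatter) from compound 2 to compound 4, at least 2.8-fold (0.45 log units) apart, beyond the scatter of two such steps Compound 3 gives only a limit, > 50000 nM, and no number, so both gaps are known only as minimum sizes, and these four compounds show that in this series the step from methoxy to methyl depends on the core, not why it does so or whether the same holds on any further core.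

The compounds shown leave open whether an ethoxy group, a chlorine or a hydroxyl group in place of the methoxy would follow the same dependence on the core. They also leave open how a benzyl group or a longer alkyl chain on the aromatic amine nitrogen, or a carboxylic acid in place of the ethyl ester, would alter these steps.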